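This account rests on a few compounds, and the source may have more. Where it says the series, first, only, none or still open, it means among the compounds named here.

Measured so far in a functional assay on Jurkat cells for inhibition of nuclear factor NF-kappa-B complex (Homo sapiens); on this read-out higher numbers stand for weaker inhibition and lower numbers for stronger inhibition:
compound 1 `CCOC(=O)c1cnc(CC)nc1NN1C(=O)C=C(C)C1=O` gives 10000 nM;
compound 2 `CCOC(=O)c1cnc(-c2cc(Cl)nc(Cl)c2)nc1NN1C(=O)C=C(C)C1=O` gives 2000 nM;
compound 3 `CCOC(=O)c1cnc(-c2ccc(F)cc2)nc1NN1C(=O)C=C(C)C1=O` gives 700 nM.

Compound 3 carries the lowest number of the three, which on this read-out means the strongest inhibition, standing apart by a 14-fold lower number from compound 1 to compound 3 (1.15 log units; beyond the scatter) and by a 2.9-fold lower number from compound 2 to compound 3 (0.46 log units; beyond the scatter). Compound 4 `CCOC(=O)c1cnc(-c2cc(Cl)cc(Cl)c2)nc1NN1C(=O)C=C(C)C1=O` has not yet been measured and differs from compound 3 in one place: 3,5-dichlorophenyl in place of 4-fluorophenyl on an aromatic carbon. Within the data shown here, two measured steps bear on this change. The step of a 14-fold lower number from compound 1 to compound 3 (1.15 log units; beyond the scatter) shows that an aromatic ring at the same place went with a much lower number, and compound 4 keeps such a ring. The step of a 2.9-fold lower number from compound 2 to compound 3 (0.46 log units; beyond the scatter) shows that a ring with two chlorines went with a higher number than the 4-fluorophenyl ring, and compound 4 again carries two chlorines, now on a ring of carbon only. A modest rise in number is therefore expected, a 1.7-fold higher number from compound 3 to compound 4 (0.23 log units; within the scatter). For compound 4 the estimate is 1200 nM, with a range from 400 nM to 3500 nM.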

Compound 4, half-maximal inhibitory concentration: 300 nM
Estimate against measurement, compound 4: 4.0-fold (0.60 log units) above, and the stated range ends above it.
By their numbers in this assay, from the lowest: compound 4; then compound 3; then compound 2; then compound 1.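

On this aromatic carbon, 3,5-dichlorophenyl goes with a 2.3-fold lower number from compound 3 to compound 4 (0.37 log units; beyond the scatter) here, so a pair of chlorines does not in itself raise the number at this position. The same two chlorines, on a ring of carbon only and placed differently from those of 2,6-dichloropyridin-4-yl, give a 6.7-fold lower number from compound 2 to compound 4 (0.82 log units; beyond the scatter) and the full change from ethyl gives a 33-fold lower number from compound 1 to compound 4 (1.52 log units; beyond the scatter) on this read-out. No measurement shown explains these steps.

Still open, from the compounds shown here alone, is whether a phenyl ring with one chlorine, or with a methoxy group or an amine at these places, would give a lower or a higher number.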